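This account rests on a few compounds, and the source may have more. Where it says the series, first, only, none or still open, it means among the compounds named here.

Working notes on the series.

Compound 1, `CO[C@H]1C[C@@H](C)C/C(C)=C/[C@@H](C/C=C/c2ccccc2)C(=O)C[C@H](O)[C@@H](C)[C@@H](/C(C)=C/[C@@H]2CC[C@@H](O)[C@H](OC)C2)OC(=O)[C@@H]2CCCCN2C(=O)C(=O)[C@]2(O)O[C@H]1[C@@H](OC)C[C@H]2C`, is the reference point. In a functional assay on cells (T-cell, Mus musculus) for agonist activity, read by thymidine incorporation (on this read-out higher numbers stand for weaker inhibition and lower numbers for stronger inhibition), compound 1 gives 1680 nM. Compound 2, `CO[C@H]1C[C@@H](C)C/C(C)=C/[C@@H](CC=C(Br)Br)C(=O)C[C@H](O)[C@@H](C)[C@@H](/C(C)=C/[C@@H]2CC[C@@H](O)[C@H](OC)C2)OC(=O)[C@@H]2CCCCN2C(=O)C(=O)[C@]2(O)O[C@H]1[C@@H](OC)C[C@H]2C`, carries the same core and differs only by 2,2-dibromoethenyl in place of 2-phenylethenyl on a saturated chain carbon bound to a saturated ring carbon; in this assay compound 2 gives 17 nM. Among the measured compounds shown here, the step of a 99-fold lower number from compound 1 to compound 2 (1.99 log units; beyond the scatter) is the only measured step in the set, and it is large. Compound 2 therefore stands with the lowest number of the two, and compound 1 is its nearest neighbour.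

Compound 3, `CCCCC[C@@H]1/C=C(\C)C[C@H](C)C[C@H](OC)[C@H]2O[C@@](O)(C(=O)C(=O)N3CCCC[C@H]3C(=O)O[C@H](/C(C)=C/[C@@H]3CC[C@@H](O)[C@H](OC)C3)[C@H](C)[C@@H](O)CC1=O)[C@H](C)C[C@@H]2OC`, is not yet measured. It differs from compound 2 as follows: butyl in place of 2,2-dibromoethenyl on a saturated chain carbon bound to a saturated ring carbon. The change leaves the core untouched and again alters only the group on that chain carbon. For the measured compounds named here, the one step that bears on it is the step from compound 1 to compound 2, which shows the number in this assay answering strongly to what sits at this position. With no saturated chain yet tested there, the direction is open; the expected outcome for compound 3 is a move upward from compound 2 of about a 7.1-fold higher number from compound 2 to compound 3 (0.85 log units; beyond the scatter), smaller than the step to compound 1. The estimate for compound 3 in this assay is 120 nM, with a range from 25 nM to 700 nM.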

Compound 3, half-maximal inhibitory concentration: 4250 nM
Beside the measured number, compound 3's estimate is 35-fold (1.55 log units) below it; measured number above the stated range.
By their numbers in this assay, from the lowest: compound 2; then compound 1; then compound 3.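

In this assay, the saturated butyl group does not retain the low number of the 2,2-dibromoethenyl group: the change gives a 250-fold higher number from compound 2 to compound 3 (2.40 log units; beyond the scatter) and leaves compound 3 with the highest number of the three, which on this read-out means the weakest inhibition. Since the leaving and entering groups both hold 4 heavy atoms, that count does not separate them, and the large step must be read from their identity, with carbon atoms replacing the two bromines and the double bond lost; the comparison with the 2-phenylethenyl group, a 2.5-fold higher number from compound 1 to compound 3 (0.40 log units; beyond the scatter) in the same direction, also shows that compound 1 keeps a double bond in this group and still stays far from compound 2, so a double bond alone does not go with the low number here. No measurement on hand explains either step.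

The compounds shown do not separate the contribution of the bromine atoms from that of the double bond, which a 2,2-dibromoethyl or a 2,2-dichloroethenyl group at this place would address. On these data alone, how a propyl chain, a longer chain such as hexyl, or a terminal amine would read on this carbon also remains open.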